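Compound 2 and its 4-bromophenyl neighbour

This account rests on a few compounds, and the source may have more. Where it says the series, first, only, none or still open, it means among the compounds named here.

In a functional assay on CCRF-CEM cells (Homo sapiens) for inhibition, read by MTT assay, with a stated time of 72 h (a higher number here means a weaker inhibitor, a lower number a stronger inhibitor), compound 1 (`COc1cc(NC(C)CCCNC(=O)Nc2cccc(F)c2)c2ncccc2c1`) gives 21000 nM and compound 2 (`COc1cc(NC(C)CCCNC(=O)Nc2cccc(Cl)c2)c2ncccc2c1`) gives 22000 nM. Among the measured compounds shown here, compound 2 thus stands level with the only other measured compound. For the measured compounds named here, the one measured step is a 1.0-fold higher number from compound 1 to compound 2 (0.02 log units; within the scatter), with chloro in place of fluoro on an aromatic carbon. Compound 3 (`COc1cc(NC(C)CCCNC(=O)Nc2ccc(Br)cc2)c2ncccc2c1`) has 4-bromophenyl in place of 3-chlorophenyl on an amide-type nitrogen. Going by the values given here, only that single halogen exchange bears on this change, and so far no measured compound carries a 4-bromophenyl group. Since the exchange gave a 1.0-fold higher number from compound 1 to compound 2 (0.02 log units; within the scatter), no step beyond the scatter is expected in this assay, although this expectation rests on thin evidence. The expected step is a 1.0-fold lower number from compound 2 to compound 3 (0.02 log units; within the scatter). For compound 3, the estimate is 21000 nM, with an expected range from 9000 nM to 48000 nM.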

Compound 3, half-maximal inhibitory concentration: 23000 nM
Beside the measured number, compound 3's estimate is 1.1-fold (0.04 log units) below it, and the stated range covers the measured number.
By their numbers in this assay, from the lowest: compounds 1, 2 and 3 (each within the scatter of the next).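

In this assay, the change at this position now alters both the halogen and the printed ring position, from 3-chlorophenyl to 4-bromophenyl, and the result is a 1.0-fold higher number from compound 2 to compound 3 (0.02 log units; within the scatter). Set against the fluoro compound, the same kind of exchange gives a 1.1-fold higher number from compound 1 to compound 3 (0.04 log units; within the scatter), so the 3-fluorophenyl, 3-chlorophenyl and 4-bromophenyl groups on the amide-type nitrogen all lie within the scatter of one another. No supporting measurement is available to explain this lack of separation.

All three compounds carry a halogen on this phenyl ring and share the same core and chain, so these results cannot show whether a group of another kind, such as an amine or a carboxylic acid on the ring, would shift the number. From the compounds shown here alone, it also remains open whether a longer chain would do so.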